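Series notes: aryl variation and tolerated concentration

The compounds below may be only part of what the source reports. "The series", "measured", "known", "first", "only" and "open" are said of these compounds alone.

Measured compounds, each in a functional assay on K562 cells (Homo sapiens) for cytotoxicity, read by sulforhodamine B assay; a higher number here means that more compound is tolerated, a lower number that less compound is tolerated:
- compound 1 `CC1=CC[C@@H]([C@@](C)(O)CCCC(C)(C)NC(=S)N/N=C\c2ccc(C)cc2)CC1`; compound 1 gives > 100000 nM, which is a limit of this assay and not a number.
- compound 2 `CC1=CC[C@@H]([C@@](C)(O)CCCC(C)(C)NC(=S)N/N=C\c2ccc(O)cc2)CC1`; compound 2 gives > 100000 nM, again a limit.
- compound 3 `CC1=CC[C@@H]([C@@](C)(O)CCCC(C)(C)NC(=S)N/N=C\c2ccccc2[N+](=O)[O-])CC1`; compound 3 gives > 100000 nM, also a limit.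

Compound 3 therefore stands at the limit of > 100000 nM in this assay, at which 3 of the 3 values shown sit, and no value in the set is a number. The steps between the measured compounds, a step that the two limits leave unreadable from compound 1 to compound 2, a step that the two limits leave unreadable from compound 1 to compound 3 and a step that the two limits leave unreadable from compound 2 to compound 3, are all unreadable for that reason; nothing here shows a readable change on swapping the aryl group.

Compound 4 `CC1=CC[C@@H]([C@@](C)(O)CCCC(C)(C)NC(=S)N/N=C\c2ccccc2Cl)CC1` differs from compound 3 by chloro in place of nitro on an aromatic carbon. Within the data shown here, no measured step bears on this change beyond the three unreadable ones, so no size of step is expected in this assay, in either direction. Compound 4 is estimated to sit at 100000 nM, within 30000 nM to 300000 nM, most probably again as a limit. The step from compound 3 to compound 4 is thus expected to be a number no higher from compound 3 to compound 4 (the limit leaves the size open).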

Compound 4, concentration lethal to 50% of the cells: 8500 nM
Estimate against measurement, compound 4: 12-fold (1.07 log units) above; measured number below the stated range.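

In this assay, among these compounds, chloro in place of nitro on an aromatic carbon, ortho to a large group, gives an at least 11-fold lower number from compound 3 to compound 4 (1.07 log units; beyond the scatter), so a change at this one position can bring the series off the limit, which the earlier compounds did not show. The 2-chlorophenyl group also separates from the other two aryl groups, with an at least 11-fold lower number from compound 2 to compound 4 (1.07 log units; beyond the scatter) and an at least 11-fold lower number from compound 1 to compound 4 (1.07 log units; beyond the scatter). The steps among compound 1, compound 2 and compound 3 cannot be read, and the three new steps are open in size, because the other compounds rest on a limit and not on a number: the limit of > 100000 nM in this assay, at which 3 of the 4 values shown sit.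

Chloro appears at only one place on the ring, so it remains open whether the group alone or the group at this place gives the number. Also open, on these data alone, is what bromo or methoxy on the same aromatic carbon would give.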